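Thiol-linked analogues of a shared core: one ring exchanged

The source may hold more compounds than are shown below. What is called first, only, known or untested is meant among the compounds shown, and "the series" means these compounds.

Measured so far in an assay on isolated protein for inhibition of retinal dehydrogenase 2 (Homo sapiens); a lower number here means a stronger inhibitor, a higher number a weaker inhibitor:
compound 1, `Cn1ncc2c(=O)n(-c3ccccc3)c(SC(C)(C)c3ccccc3)nc21`, compound 1 gives 2200 nM
compound 2, `O=c1c2cncn2nc(SCc2cccc(F)c2)n1-c1ccccc1`, compound 2 gives 1600 nM

Of the compounds shown here, two built on the same core have been measured in this assay. Compound 1 shows the highest of the two numbers, but its nearest neighbour, compound 2, lies within the scatter of it, so the two values cannot be told apart in this assay; neither can be called the stronger inhibitor on these numbers alone.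

The next compound, compound 3, is `CC(Sc1nc2c(cnn2C)c(=O)n1-c1ccccc1)c1cccnc1`. It is drawn from compound 1 by a single change on the sulfur whose other neighbour is an aromatic carbon: 1-(pyridin-3-yl)ethyl in place of 1-methyl-1-phenylethyl on a sulfur. Going by the values given here, no pair of measured compounds here shares this kind of change, so the data give no step of known size to lean on.

With nothing in the measured pair pointing either way, the step from compound 1 to compound 3 is expected to be small, most likely none beyond the scatter, and is estimated as a 1.2-fold lower number from compound 1 to compound 3 (0.09 log units; within the scatter). Compound 3 is therefore expected to give about 1800 nM in this assay, within a range from 500 nM to 6000 nM.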

Compound 3, half-maximal inhibitory concentration: 89 nM
Compound 3: the middle estimate sits 20-fold (1.31 log units) above what was measured, and the stated range ends above it.
By their numbers in this assay, from the lowest: compound 3; then compounds 2 and 1 (each within the scatter of the next).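

In this assay, the group on a sulfur whose other neighbour is an aromatic carbon turns out to matter far more than compounds 1 and 2, whose values lay within the scatter of each other, could suggest: the exchange gives a 25-fold lower number from compound 1 to compound 3 (1.39 log units; beyond the scatter), a large step beyond the scatter. This single step bundles two differences, since the carbon-only aromatic ring of 1-methyl-1-phenylethyl gives way to a ring with a hetero atom and a hydrogen-bond acceptor, while the 1-methyl of the leaving group is also lost, so the step cannot be divided between them. No measurement available here accounts for the size of this step.

The compounds shown leave open which of the two differences carries the step, a question that a 1-phenylethyl group on the same sulfur would separate. They also leave open whether the place of the ring nitrogen matters, as a 1-(pyridin-2-yl)ethyl or 1-(pyridin-4-yl)ethyl group on that sulfur would show when set against compound 3.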